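Swapping benzyl for nitrophenyl on the ether oxygen

A few compounds are considered here, and "the series" means these few. Any claim that something is new, unique, unknown or untested is made for them only; others in the source may bear on it.

Compound 1 `O=[N+]([O-])c1ccc(NC(=S)NCCNS(=O)(=O)c2ccc(-c3ccccc3O[C@H]3CC[C@@H](O)CC3)s2)cc1`: > 50000 nM
Compound 2 `O=C(NCCNS(=O)(=O)c1ccc(-c2ccccc2O[C@H]2CC[C@H](O)CC2)s1)Nc1cc(Cl)cc(Cl)c1`: > 20000 nM
Compound 3 `O=S(=O)(NCCNC(=S)Nc1cc(C(F)(F)F)cc(C(F)(F)F)c1)c1ccc(-c2ccccc2OCc2ccccc2)s1`: 2100 nM

All three were tested in a functional assay on HL-60 cells (Homo sapiens) for inhibition, read by CCK-8 assay, with a stated time of 48 h; on this read-out higher numbers stand for weaker inhibition and lower numbers for stronger inhibition. For compound 1 the value > 50000 nM is a limit of the assay, not a number. For compound 2 the value > 20000 nM is likewise a limit. For the measured compounds named here, compound 3 is therefore the only compound with a measured number, 2100 nM, and stands as the single fixed point. Compound 4 `O=[N+]([O-])c1ccc(Oc2ccccc2-c2ccc(S(=O)(=O)NCCNC(=S)Nc3cc(C(F)(F)F)cc(C(F)(F)F)c3)s2)cc1` has not yet been measured. It differs from compound 3 in one place: 4-nitrophenyl in place of benzyl on an oxygen on an aromatic ring. Going by the values given here, no step between two measured compounds exists to guide this change, so its direction is open. The expected step, a 1.4-fold higher number from compound 3 to compound 4 (0.15 log units; within the scatter), is small and may not exceed the usual scatter. Compound 4 is estimated at 3000 nM, with a range from 900 nM to 10000 nM.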

Compound 4, half-maximal inhibitory concentration: 7200 nM
Compound 4: the middle estimate sits 2.4-fold (0.38 log units) below what was measured; measured number inside the range.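

In this assay putting 4-nitrophenyl in place of benzyl on an oxygen on an aromatic ring gives a 3.4-fold higher number from compound 3 to compound 4 (0.54 log units; beyond the scatter) and so weaker inhibition. For the compounds shown here, both compounds carry real numbers rather than limits, so this is the first change whose size can be read, and it shows that the group at this place matters, though modestly. Nothing measured here says why the step runs in this direction. As far as these compounds go, how a plain phenyl, without the nitro group, or a chain ending in an amine would behave on that oxygen stays open.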